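A few compounds are considered here, and "the series" means these few. Any claim that something is new, unique, unknown or untested is made for them only; others in the source may bear on it.

In an ADME assay on a cell-free system (plasma, Rattus norvegicus) for metabolic stability, read by LC-MS, with a stated time of 60 min, tested at 100 uM (on this read-out lower numbers stand for a less stable compound and higher numbers for a more stable compound), compound 1 (`Cc1cc(C(=O)O)ccc1OCCCCOc1ccc(C(=O)CC(C)C)c(O)c1C`) gives 100% and lies within the scatter of compound 3 (`Cc1c(OCCCCOc2cccc(C(=O)O)c2)ccc(C(=O)CC(C)C)c1C`) at 106% while compound 2 (`Cc1c(OCCCCOc2ccc(C(=O)O)cc2Cl)ccc(C(=O)CC2CCCC2)c1O`) at 120% stands higher than compound 1 by more than the scatter. None of the three shows a loss of material. Compound 4 (`Cc1cc(OCCCCOc2ccc(C(=O)CC(C)C)c(O)c2C)ccc1C(=O)O`) differs from compound 1 by 4-carboxy-3-methylphenyl in place of 4-carboxy-2-methylphenyl on an oxygen on a saturated carbon and has the same atoms joined differently. Among the compounds with values here, no measured pair isolates a change of this kind, so the expectation rests only on the absence of loss across the three measured compounds. The estimated step of a number 4 percentage points higher from compound 1 to compound 4 (within the scatter) is expected to stay within the scatter, with no firm direction. Compound 4 is estimated at 104% (expected range 92% to 118%).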

Compound 4, percent of the compound remaining: 101%
Compound 4: the middle estimate sits 3 percentage points above what was measured, and the stated range covers the measured number.
By their numbers in this assay, from the lowest: compounds 1, 4 and 3 (each within the scatter of the next); then compound 2.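

In this assay the change to 4-carboxy-3-methylphenyl from 4-carboxy-2-methylphenyl gives a number 1 percentage points higher from compound 1 to compound 4 (within the scatter) as the only single-place comparison shown. At this place on an oxygen on a saturated carbon, joining the same atoms differently therefore leaves the read-out within the scatter, with no loss of material in compound 4. No measured information here bears on the reason for this result.

Still open, as far as these compounds go, is how the read-out responds to a methoxy group on this ring or to an amide in place of the carboxylic acid.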